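Replacing isopropyl with 4-fluorophenyl in compound 2

A few compounds are considered here, and "the series" means these few. Any claim that something is new, unique, unknown or untested is made for them only; others in the source may bear on it.

Values measured in an ADME assay on WI-38 cells (Homo sapiens) for cytotoxicity, read by MTT assay, with a stated time of 72 h (a lower number here means a stronger inhibitor, a higher number a weaker inhibitor), are as follows
compound 1 `CCNC(=O)CCc1cccc2c1B(O)OC2` gives > 100000 nM
compound 2 `CC(C)c1cccc(NC(=O)CCc2cccc3c2B(O)OC3)c1` gives 22000 nM

The value of compound 1 is a limit of the assay and not a number. For the measured compounds named here, compound 2 therefore holds the only actual number in this assay, standing at 22000 nM without any measured step to compare it with.

Compound 3 `O=C(CCc1cccc2c1B(O)OC2)Nc1cccc(-c2ccc(F)cc2)c1` has 4-fluorophenyl in place of isopropyl on an aromatic carbon, meta to a large group (4-fluorophenyl in place of isopropyl on an aromatic carbon). Going by the values given here, with no measured step to draw on, the expectation rests only on this structural change and on compound 2 at 22000 nM as the starting point. A modest move towards a lower number is expected, an estimated step of a 1.8-fold lower number from compound 2 to compound 3 (0.26 log units; within the scatter) that may not clear the usual scatter by much. For compound 3 the expected value is 12000 nM (estimated range 4000 nM to 40000 nM).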

Compound 3, half-maximal inhibitory concentration: 4100 nM
Compound 3: middle estimate off by 2.9-fold (0.47 log units), on the high side, within the range that was stated.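

In this assay, putting 4-fluorophenyl in place of isopropyl gives a 5.4-fold lower number from compound 2 to compound 3 (0.73 log units; beyond the scatter), so the read-out responds to the group on this aromatic carbon, meta to a large group. Compound 2 alone could not show this, as a single number says nothing about how far a change at this place can move the value; the step shows that the larger aromatic group goes with a stronger effect on the cells. Compound 1 remains a limit of the assay and not a number, so it offers no step of its own: the limit of > 100000 nM in this assay, at which 1 of the 3 values shown sits.

The compounds shown leave open whether the step belongs to the added ring or to its fluorine, a question that a plain phenyl at the same place would settle. Going by these compounds, how an amine or a carboxylic acid on this carbon would read in this assay also remains open.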